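Aminotriazolopyridazine series: anilino-type thiophene replacing N-methyl

The source may report more compounds than this note shows. Statements on the series, on what has been measured and on what is new or still open speak of the compounds shown alone.

Compound 1 `CNc1nncc2c(C)ncn12` gives > 48000 nM in a functional assay for inhibition, with Homo sapiens as the target; a lower number here means a stronger inhibitor, a higher number a weaker inhibitor; this is a limit of the assay.
Compound 2 `Cc1ncn2c(NCc3ccco3)nncc12` gives > 48000 nM in this assay, again a limit.

Among the compounds with values here, compound 1 therefore stands only at a limit, as does the one other value shown, with the step that the two limits leave unreadable from compound 1 to compound 2 unreadable, as the limit of > 48000 nM in this assay, at which 2 of the 2 values shown sit, records. Compound 3 `Cc1ncn2c(Nc3cccs3)nncc12` differs from compound 1 by thiophen-2-yl in place of methyl on a nitrogen on an aromatic ring. Within the data shown here, no measured step bears on that change; the measured steps lie between limits and give no size at all. Compound 3 is expected to stay at a limit, with a step that the limit leaves unreadable from compound 1 to compound 3 giving an estimate of 60000 nM (range 15000 nM to 250000 nM).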

Compound 3, half-maximal inhibitory concentration: > 48000 nM
Compound 3 gave a limit, no number; the forecaster's own chance of this, stated with the estimate: 80%; the middle value does not contradict the limit.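

In this assay compound 3 gives > 48000 nM as a limit. Within the data shown here, compound 1 also stands at a limit, so no step between compound 1 and compound 3 can be read. The compounds shown leave open which group on the nitrogen, if any, would give a measurable value: the limit of > 48000 nM in this assay, at which 3 of the 3 values shown sit.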